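Piperazine substituent change on the shared core

The source may hold more compounds than are shown below. What is called first, only, known or untested is meant among the compounds shown, and "the series" means these compounds.

Two compounds of the series have been run in a functional assay on MDA-MB-231 cells (Homo sapiens) for antiproliferative activity, read by MTT assay, with a stated time of 48 h; on this read-out lower numbers stand for stronger inhibition and higher numbers for weaker inhibition. Compound 1 `C=CS(=O)(=O)N1CCN(c2ncnc3sc(-c4ccc(F)nc4)cc23)CC1` gives 16000 nM in this assay. Compound 2 `CCS(=O)(=O)N1CCN(c2ncnc3sc(-c4ccc(N5CCN(C)CC5)cc4)cc23)CC1` gives 7330 nM in this assay, the lower of the two numbers, with compound 1 standing higher by a margin beyond the scatter. Compound 3 `COc1ccccc1NC(=O)N1CCN(c2ncnc3sc(-c4ccc(N5CCN(C)CC5)cc4)cc23)CC1` carries (2-methoxyphenyl)carbamoyl in place of ethylsulfonyl on an amine nitrogen in a ring. Among the measured compounds shown here, no measured step of this kind is available, so the step from compound 2 to compound 3 is expected to be small, toward stronger inhibition and probably within the scatter, as a 1.5-fold lower number from compound 2 to compound 3 (0.17 log units; within the scatter). Compound 3 is therefore expected to give about 5000 nM in this assay, in the range 1500 nM to 15000 nM.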

Compound 3, half-maximal inhibitory concentration: 23200 nM
The estimate for compound 3 lay 4.6-fold (0.67 log units) below the measured number; measured number outside the range, above it.
By their numbers in this assay, from the lowest: compound 2; then compounds 1 and 3 (each within the scatter of the next).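

In this assay, among the compounds shown here, (2-methoxyphenyl)carbamoyl in place of ethylsulfonyl on the amine nitrogen in the ring gives a 3.2-fold higher number from compound 2 to compound 3 (0.50 log units; beyond the scatter), a modest step toward weaker inhibition and the first single-place reading at this position. The change adds an aromatic ring and a hydrogen-bond donor together, so the step cannot be assigned to either one. No supporting data bear on the reason for this step.

Open, from the compounds shown here alone, is whether an unsubstituted phenylcarbamoyl or a simple acetyl on this nitrogen would read closer to compound 2 or to compound 3. Also open, going by these compounds, is whether the methoxy group on the phenyl ring contributes to the step.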